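The source may report more compounds than this note shows. Statements on the series, on what has been measured and on what is new or still open speak of the compounds shown alone.

Measured so far: compound 1 `O=C(C1CCN(Cc2ccccc2)CC1)N1CCc2ccccc2C1` with 8.8 nM; compound 2 `O=C(C1CCN(Cc2ccc(Cl)cc2Cl)CC1)N1CCCc2ccccc21` with 138 nM; compound 3 `O=C(C1CCN(Cc2ccc(Cl)cc2)CC1)N1CCc2ccccc2C1` with 8 nM.

These values come from an assay for displacement of a labelled ligand from Sigma non-opioid intracellular receptor 1 (Cavia porcellus); on this read-out higher numbers stand for weaker inhibition and lower numbers for stronger inhibition. Compound 3 and compound 1 share one core and differ by hydrogen in place of chloro on an aromatic carbon; that step, a 1.1-fold higher number from compound 3 to compound 1 (0.04 log units; within the scatter), lies within the scatter. Compound 4 `O=C(C1CCN(Cc2ccc(Cl)cc2)CC1)N1CCCc2ccccc21` has not yet been measured in this assay. It differs from compound 2 by hydrogen in place of chloro on an aromatic carbon. This is the same kind of change, though here the place is ortho to a large group and meta to a chloro group, whereas in the first pair it was para to a large group. The difference between the cores of compound 2 and compound 3 is not broken down here; compound 2 gives the highest number of the three. For compound 4 the expected step is a 1.5-fold lower number from compound 2 to compound 4 (0.16 log units; within the scatter). This rests on compound 3 and compound 1, whose step a 1.1-fold higher number from compound 3 to compound 1 (0.04 log units; within the scatter) hardly moved the number. Compound 4 is thus estimated at 95 nM, between 30 nM and 300 nM.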

Compound 4, inhibition constant: 3.7 nM
The estimate for compound 4 lay 26-fold (1.41 log units) above the measured number, outside the stated range (below it).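

In this assay, going from 2,4-dichlorobenzyl to 4-chlorobenzyl gives a 37-fold lower number from compound 2 to compound 4 (1.57 log units; beyond the scatter). Hydrogen in place of chloro therefore did not carry over as a step of one size from one core to the other: the same change on two cores in this assay, a 1.1-fold higher number (0.04 log units; within the scatter) from compound 3 to compound 1 and a 37-fold lower number (1.57 log units; beyond the scatter) from compound 2 to compound 4, 41-fold (1.61 log units) apart, beyond the scatter of two such steps

This does not show that the core alone sets the size of the step, as the two pairs differ in the core and also in where the chloro group leaves, which in compound 2 is ortho to a large group and meta to a chloro group. The compounds shown leave open how a 2,4-dichlorobenzyl group behaves on the core of compound 1, which would separate place from core. Also open, going by these compounds, is whether a fluoro or methoxy group in that same place on the core of compound 4 would give a number like that of compound 2.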